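The source may hold more compounds than are shown below. What is called first, only, known or untested is meant among the compounds shown, and "the series" means these compounds.

Compound 1 `CC(C)n1cnc2c(Nc3ccccc3)nc(NCOCc3ccc(C(=O)Nc4ccccc4N)cc3)nc21` and compound 2 `CC(C)n1cnc2c(NCc3ccc(C(=O)Nc4ccccc4N)cc3)nc(Cl)nc21` were both tested in a functional assay on HCT-116 cells (Homo sapiens) for antiproliferative activity, read by CCK-8 assay, with a stated time of 72 h, tested at 2 uM; on this read-out higher numbers stand for a stronger effect at the one concentration tested and lower numbers for a weaker effect. The difference between the two cores is not broken down here. In this assay compound 1 gives 6.85%, while compound 2 gives 73.2%. Compound 3 `Nc1ccccc1NC(=O)c1ccc(CNc2nc(Cl)nc3c2ncn3C2CCCC2)cc1` differs from compound 2 in one place: cyclopentyl in place of isopropyl on an aromatic nitrogen. In this assay compound 3 gives 75.6%, so this change made a step of a number 2.4 percentage points higher from compound 2 to compound 3 (within the scatter). Compound 4 `Nc1ccccc1NC(=O)c1ccc(COCNc2nc(Nc3ccccc3)c3ncn(C4CCCC4)c3n2)cc1` carries the same change on compound 1: cyclopentyl in place of isopropyl on an aromatic nitrogen. For compound 4 the step from compound 1 is expected to be small, namely a number 2.2 percentage points higher from compound 1 to compound 4 (within the scatter), because the earlier step of a number 2.4 percentage points higher from compound 2 to compound 3 (within the scatter) stayed within the scatter. Compound 4 is therefore expected to give about 9% in this assay. The estimate for compound 4 is expected to fall between 0% and 25%.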

Compound 4, a percentage reported as inhibition, at one concentration (the size of the read-out at that concentration, not a potency): 75.2%
For compound 4 the middle estimate is 66.2 percentage points below the measured one, and the stated range ends below it.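

In this assay cyclopentyl in place of isopropyl on an aromatic nitrogen made a step of a number 68.4 percentage points higher from compound 1 to compound 4 (beyond the scatter) and so the same change does not have the same size on the two cores: the same change on two cores in this assay, a number 2.4 percentage points higher (within the scatter) from compound 2 to compound 3 and a number 68.4 percentage points higher (beyond the scatter) from compound 1 to compound 4, 66 percentage points apart, beyond the scatter of two such steps.
In this series, then, a small step on one core gave no safe guide to the step on another. This rests on one pair of compounds per core, so it does not show why the two steps differ or what the change would do on any further core.
The compounds shown leave open how a methyl, a cyclobutyl or a cyclohexyl on that aromatic nitrogen would compare with isopropyl and cyclopentyl. They also leave open whether the size of the step follows the size of this group on either core.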